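The compounds below may be only part of what the source reports. "The series", "measured", "known", "first", "only" and "open" are said of these compounds alone.

Measured so far:
Compound 1 `C=Cc1nc2ccccc2[se]1`: 12200 nM
Compound 2 `C=Cc1nc2ccccc2s1`: > 40000 nM (a limit of the assay)

Among the measured compounds shown here, in a functional assay on NCI-H522 cells (Homo sapiens) for cytotoxicity, with a stated time of 3 days (a lower number here means a stronger inhibitor, a higher number a weaker inhibitor), compound 1 gives 12200 nM, and this is the only true number available for the series. Compound 2 is reported only as a limit, > 40000 nM, so it offers no number to work from.

Attention now turns to compound 3 `C#Cc1nc2ccccc2[se]1`, which keeps the core of compound 1 and differs from it in one place. It carries ethynyl in place of vinyl on an aromatic carbon of a five-membered aromatic ring with 1 nitrogen and 1 selenium (ethynyl in place of vinyl on an aromatic carbon). The swap leaves the size of the group unchanged, and a triple bond replaces the double bond outside the aromatic rings.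

For the measured compounds named here, no measured pair provides a step that could size this change in this assay, so the expectation is tentative and rests on compound 1 at 12200 nM. A moderate shift toward stronger inhibition is expected, with a 2.4-fold lower number from compound 1 to compound 3 (0.39 log units; beyond the scatter) as the estimated step. For compound 3 the estimated value is 5000 nM, with an expected range of 900 nM to 30000 nM.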

Compound 3, half-maximal inhibitory concentration: 2170 nM
For compound 3 the middle estimate is 2.3-fold (0.36 log units) above the measured one, and the stated range covers the measured number.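

In this assay, ethynyl in place of vinyl on this aromatic carbon, next to the ring nitrogen and next to the ring selenium, gives a 5.6-fold lower number from compound 1 to compound 3 (0.75 log units; beyond the scatter). Among the compounds shown here, this is the first step that can be sized, and it shows that the number at this position responds even to a swap that leaves the size of the group unchanged. The two groups match in everything counted here, with no ring, no hydrogen-bond donors or acceptors and no net charge, and differ only in a triple bond replacing a double bond outside the aromatic rings.

Steps involving compound 2 cannot be read, since compound 2 is reported only as a limit of the assay and not as a number: the limit of > 40000 nM in this assay, at which 1 of the 3 values shown sits. From the compounds shown here alone, it remains open whether ethynyl would give a comparable step on the core of compound 2, and how other groups on this carbon, such as a nitrile, an amine or a longer chain, would compare with vinyl and ethynyl.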